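A few compounds are considered here, and "the series" means these few. Any claim that something is new, unique, unknown or untested is made for them only; others in the source may bear on it.

Measured compounds in hand:
compound 1 `Cc1ccc(CS/C(=C/c2ccc(O)cc2)C(=O)c2ccc(Cl)cc2)cc1` — 10000 nM
compound 2 `Cc1ccc(CS/C(=C/c2c(O)cc(O)cc2O)C(=O)c2ccc(Cl)cc2)cc1` — 50000 nM
compound 3 `Cc1ccc(CS/C(=C/c2sccc2C)C(=O)c2ccc(Cl)cc2)cc1` — 10000 nM

In a functional assay on DU-145 cells (Homo sapiens) for inhibition, read by trypan blue exclusion, with a stated time of 96 h (on this read-out lower numbers stand for stronger inhibition of growth and higher numbers for weaker inhibition of growth), compound 2 gives the highest of the three numbers, 50000 nM, and is thus the weakest inhibitor of growth in the set: the step of a 5.0-fold higher number from compound 1 to compound 2 (0.70 log units; beyond the scatter) and the step of a 5.0-fold lower number from compound 2 to compound 3 (0.70 log units; beyond the scatter) both lie beyond the scatter, while compound 1 and compound 3 sit within the scatter of each other, as the step of no change at the digits printed from compound 1 to compound 3 (within the scatter) shows.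

Compound 4 `O=C(/C(=C\c1c(O)cc(O)cc1O)SCc1ccc(Cl)cc1Cl)c1ccc(Cl)cc1` is the next compound to be measured in this assay. It differs from compound 2 in one place: 2,4-dichlorophenyl in place of 4-methylphenyl on a saturated chain carbon bound to a sulfur.

Every step measured so far changes the group on the double-bonded chain carbon, and the (4-methylbenzyl)sulfanyl part is kept constant in compound 1, compound 2 and compound 3. Going by the values given here, no measured step therefore bears on the exchange of 4-methylbenzyl for 2,4-dichlorobenzyl on the saturated chain carbon bound to a sulfur, and the data give no direction for it. The working expectation is a step of no more than the scatter from compound 2 to compound 4, that is no change at the digits printed from compound 2 to compound 4 (within the scatter), with a wide range on either side. On that basis compound 4 is estimated at 50000 nM in this assay, between 15000 nM and 150000 nM.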

Compound 4, concentration for 50% growth inhibition: 25000 nM
Estimate against measurement, compound 4: 2.0-fold (0.30 log units) above, and the stated range covers the measured number.
By their numbers in this assay, from the lowest: compounds 1 and 3 (each within the scatter of the next); then compounds 4 and 2 (each within the scatter of the next).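

Going by these compounds alone, this is the first reading at the saturated chain carbon bound to a sulfur, as all earlier steps changed the group on the double-bonded chain carbon. In this assay the exchange of 4-methylbenzyl for 2,4-dichlorobenzyl gives a 2.0-fold lower number from compound 2 to compound 4 (0.30 log units; within the scatter), so replacing the methyl group with two chlorine atoms on this ring produces no shift beyond the scatter, at least with 2,4,6-trihydroxyphenyl kept on the double-bonded chain carbon. Nothing on hand accounts for this outcome or separates the removal of the methyl group from the addition of either chlorine atom.

Still open, on these data alone, is whether the same exchange would read alike with the 4-hydroxyphenyl of compound 1 or the 3-methylthiophen-2-yl of compound 3, as the exchange has been read only on the 2,4,6-trihydroxyphenyl background. Also open, as far as these compounds go, is how this position responds to groups of another kind, such as an amine or a carboxylic acid on the ring, or to a longer chain in place of the saturated chain carbon bound to a sulfur.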